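Benzofuranyl nucleoside: from dimethylamino to methyl

The source may report more compounds than this note shows. Statements on the series, on what has been measured and on what is new or still open speak of the compounds shown alone.

Measured in a functional assay on HepG2 cells (Homo sapiens) for antiproliferative activity, read by XTT assay, with a stated time of 72 h; on this read-out higher numbers stand for weaker inhibition and lower numbers for stronger inhibition:
- Compound 1 `CN(C)c1ncnc2c1c(-c1ccsc1)cn2[C@@H]1O[C@H](CO)[C@@H](O)[C@H]1O`: > 20000 nM, a limit
- Compound 2 `CN(C)c1ncnc2c1c(-c1cc3ccccc3o1)cn2[C@@H]1O[C@H](CO)[C@@H](O)[C@H]1O`: > 20000 nM, a limit

Among the measured compounds shown here, compound 2 stands at a limit and not at a number, with > 20000 nM as its only reading. For the measured compounds named here, the series so far offers only (the limit of > 20000 nM in this assay, at which 2 of the 2 values shown sit). The change to compound 3 `Cc1ncnc2c1c(-c1cc3ccccc3o1)cn2[C@@H]1O[C@H](CO)[C@@H](O)[C@H]1O` is methyl in place of dimethylamino on an aromatic carbon, next to the ring nitrogen: methyl in place of dimethylamino on an aromatic carbon.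

Going by the values given here, the only measured step is a step that the two limits leave unreadable from compound 1 to compound 2. Among the compounds with values here, it concerns the other substituent and gives no size to carry over, so no measured step bears directly on this change. Compound 2 sits at > 20000 nM, a limit, so in this assay only a move toward stronger inhibition could appear as a number. A modest move of that kind is expected, though the result may again be only a limit. The expected step is an at least 2.2-fold lower number from compound 2 to compound 3 (0.34 log units; beyond the scatter). The estimated value for compound 3 is 9000 nM, with an expected range of 1500 nM to 20000 nM.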

Compound 3, half-maximal inhibitory concentration: > 20000 nM
Compound 3 ended at the assay's limit (the forecaster's own chance of this, stated with the estimate: 50%); at least 2.2-fold (0.34 log units) between middle value and limit.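

Among the compounds shown here, compound 2 and compound 3 both stand at a limit in this assay, not at a number, so the change from dimethylamino to methyl gives no step that can be read. The compounds shown leave open whether either substituent change alters antiproliferative activity at all, with a single reading across the series: the limit of > 20000 nM in this assay, at which 3 of the 3 values shown sit.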